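Swapping the Amide Aryl Group on the Shared Core

The compounds below may be only part of what the source reports. "The series", "measured", "known", "first", "only" and "open" are said of these compounds alone.

Measured compounds:
compound 1, `Cc1cccc(NC(=O)CN2CCC(c3cccc(F)c3)CC2)c1`, 512 nM
compound 2, `Cc1cc(C)cc(NC(=O)CN2CCC(c3cccc[n+]3[O-])CC2)c1`, 52 nM
compound 3, `C=Cc1cccc(C(=O)NCN2CCC(c3cccc[n+]3[O-])CC2)c1`, 68 nM

Three compounds were tested in a functional assay on HEK293 cells for agonist activity at D(4) dopamine receptor (Homo sapiens), read by FLIPR; on this read-out lower numbers stand for an effect already at smaller amounts and higher numbers for an effect only at larger amounts of compound. Compound 2 returns the lowest number of the three. Compound 3 sits within the usual scatter of compound 2, so no order can be read between these two. Compound 1, which carries a different aryl group on the piperidine as well as a different amide aryl group, returns a clearly higher number than compound 2, beyond the scatter.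

Compound 4, `O=C(CN1CCC(c2cccc[n+]2[O-])CC1)Nc1ccc(F)cc1`, differs from compound 2 in one place: 4-fluorophenyl in place of 3,5-dimethylphenyl on an amide-type nitrogen. Within the data shown here, no measured pair shows this exact change, so its size has to be estimated rather than read off. Given that compound 2 gives 52 nM while the least active compound 1 gives 512 nM, a moderate rise is expected, beyond the scatter but smaller than the spread already seen. Compound 4 is therefore expected to give about 150 nM in this assay, with a likely range from 50 nM to 500 nM, which corresponds to an estimated step of a 2.9-fold higher number from compound 2 to compound 4 (0.46 log units; beyond the scatter).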

Compound 4, half-maximal effective concentration: 85 nM
Compound 4: the middle estimate sits 1.8-fold (0.25 log units) above what was measured; low and high end bracket the measured number.
By their numbers in this assay, from the lowest: compounds 2, 3 and 4 (each within the scatter of the next); then compound 1.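

In this assay, among these compounds, this is the first change measured in one place alone, and replacing 3,5-dimethylphenyl with 4-fluorophenyl on the amide-type nitrogen gives a 1.6-fold higher number from compound 2 to compound 4 (0.21 log units; within the scatter) on the shared core. This position therefore holds either of these two substituted phenyl groups with no difference that can be read, although the two differ in their substituents and the entering group has one heavy atom fewer. Nothing measured here speaks to the cause of this result.

From the compounds shown here alone, what remains open is whether the same holds for an unsubstituted phenyl group, or for a single methyl or fluorine at either printed ring position. Going by these compounds, it is also open how this position would respond to something other than a substituted phenyl group, such as a pyridine ring, a cyclohexyl ring or a carboxylic acid on the phenyl ring.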